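Swapping an Aryl Substituent on a Benzamide Terminus

The source may hold more compounds than are shown below. What is called first, only, known or untested is meant among the compounds shown, and "the series" means these compounds.

Measured so far:
- Compound 1, `Cc1ccc(S(=O)(=O)N[C@@H](CC(=O)NC(C)(C)C)C(=O)NCCNC(=O)c2ccccc2)cc1`: 137 nm/s
- Compound 2, `Cc1ccc(S(=O)(=O)N[C@@H](CC(=O)NC(C)(C)C)C(=O)NCCNC(=O)c2ccccc2F)cc1`: 105 nm/s
- Compound 3, `Cc1ccc(S(=O)(=O)N[C@@H](CC(=O)NC(C)(C)C)C(=O)NCCNC(=O)c2ccc(F)cc2)cc1`: "not determined" (no result reported)

All three share the same core and differ only in the aromatic ring attached to the terminal amide carbonyl. In an ADME assay for permeability, using PAMPA, at pH 7.4 (a lower number here means that the compound crosses the layer more slowly, a higher number that the compound crosses the layer faster), compound 1 gives 137 nm/s. In this assay compound 2 gives 105 nm/s, and the change a 1.3-fold lower number from compound 1 to compound 2 (0.12 log units; within the scatter) lies within the scatter, so the two compounds cannot be told apart on this read-out. For compound 3 the outcome in this assay is "not determined" (no result reported), so it stands nowhere on the numbers: there is no value to anchor it.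

Compound 4, `C#Cc1cccc(C(=O)NCCNC(=O)[C@H](CC(=O)NC(C)(C)C)NS(=O)(=O)c2ccc(C)cc2)c1`, is the next step: 3-ethynylphenyl in place of 4-fluorophenyl on a carbonyl carbon. Going by the values given here, no measured pair mirrors this exchange, so the only guide is that the one substituent change seen here, from compound 1 to compound 2, stayed within the scatter. On that basis no shift beyond the scatter is expected in this assay for compound 4, and its value is estimated at 120 nm/s, with a likely range from 55 nm/s to 260 nm/s.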

Compound 4, apparent permeability: 203 nm/s
Compound 4: middle estimate off by 1.7-fold (0.23 log units), on the low side; the range from low to high includes it.
By their numbers in this assay, from the lowest: compounds 2, 1 and 4 (each within the scatter of the next).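

Ethynyl is the first group on this aromatic ring that is not a fluoro, and the ring on the carbonyl carbon carries it with no step beyond the scatter in this assay (a 1.5-fold higher number from compound 1 to compound 4 (0.17 log units; within the scatter)). The exchange of 2-fluorophenyl for 3-ethynylphenyl at the same place also stays inside the scatter (a 1.9-fold higher number from compound 2 to compound 4 (0.29 log units; within the scatter)), so compounds 1, 2 and 4 cannot be separated on this read-out. No outside evidence bears on these small steps, so they come without an explanation.

The step from compound 3 to compound 4 cannot be read, as compound 3 has no number. From the compounds shown here alone, whether a ring carrying an amine or a carboxylic acid in this place would also stay within the scatter remains open.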